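The source may hold more compounds than are shown below. What is called first, only, known or untested is meant among the compounds shown, and "the series" means these compounds.

Measured so far in an assay on Flp-In-CHO cells for displacement of a labelled ligand from adenosine receptor A1 (Homo sapiens), read by radioligand binding; a lower number here means a stronger inhibitor, a higher number a weaker inhibitor:
compound 1, `CCCn1c(=O)c2[nH]c(C34CCC(C(=O)NCCCNC(=O)COCCOCCNC(=O)OC(C)(C)C)(CC3)CC4)nc2n(CCC)c1=O`, 22.4 nM
compound 2, `CCCn1c(=O)c2[nH]c(C34CCC(C(=O)NCCNC(=O)CCNC(=O)CCNC(=O)CCCCC[N+]5=C(/C=C/C=C/C=C6/N(C)c7ccc(S(=O)(=O)O)cc7C6(C)C)C(C)(C)c6cc(S(=O)(=O)[O-])ccc65)(CC3)CC4)nc2n(CCC)c1=O`, 200 nM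
compound 3, `CCCn1c(=O)c2[nH]c(C34CCC(CCC(=O)NCCNC(=O)COCCOCCNC(=O)OC(C)(C)C)(CC3)CC4)nc2n(CCC)c1=O`, 13.2 nM

Compound 3 sits at the lowest of these three numbers. Its nearest neighbour is compound 1, and that gap lies within the scatter, so no order can be read between compound 3 and compound 1. Compound 2 lies furthest from compound 3, and that gap is beyond the scatter.

Compound 4, `CCCn1c(=O)c2[nH]c(C34CCC(CCC(=O)NCCNC(=O)COCCNC(=O)OC(C)(C)C)(CC3)CC4)nc2n(CCC)c1=O`, is the next step from compound 3. The change is (tert-butoxycarbonyl)amino in place of 2-((tert-butoxycarbonyl)amino)ethoxy on a saturated chain carbon, two bonds along the chain from an oxygen on a saturated carbon. Among the compounds with values here, no measured pair here tracks a change of this kind, so the step is expected to be small, with no direction beyond the scatter; the estimated step of a 1.1-fold higher number from compound 3 to compound 4 (0.06 log units; within the scatter) reflects this. In this assay compound 4 is expected to give 15 nM, with a range from 6 nM to 40 nM.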

Compound 4, inhibition constant: 14.8 nM
For compound 4 the middle estimate is 1.0-fold (0.01 log units) above the measured one, within the range that was stated.
By their numbers in this assay, from the lowest: compounds 3, 4 and 1 (each within the scatter of the next); then compound 2.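

In this assay, (tert-butoxycarbonyl)amino in place of 2-((tert-butoxycarbonyl)amino)ethoxy gives a 1.1-fold higher number from compound 3 to compound 4 (0.05 log units; within the scatter), so the two compounds cannot be told apart. Within the data shown here, this is the first pair here that differs in one place, and it shows that at this saturated chain carbon, the group with fewer heavy atoms brings no step beyond the scatter. Nothing available bears on why the two compounds read alike. Still open, as far as these compounds go, is whether a free amine or a carboxylic acid at this place would read the same. From the compounds shown here alone, a still longer chain than in compound 3 is equally open.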